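Replacing the 2-Fluorophenyl Group in Compound 1

The compounds below may be only part of what the source reports. "The series", "measured", "known", "first", "only" and "open" are said of these compounds alone.

Compound 1, `CCCSc1nc(N/N=C/c2ccccc2F)c2nnn(Cc3ccccc3)c2n1`, gives > 64000 nM in a functional assay on ECa-109 cells (Homo sapiens) for antiproliferative activity, read by MTT assay, with a stated time of 72 h (on this read-out lower numbers stand for stronger inhibition and higher numbers for weaker inhibition), which is a limit of the assay rather than a number.
Compound 2, `CCCSc1nc(N/N=C/c2ccc(N(C)C)cc2)c2nnn(Cc3ccccc3)c2n1`, gives 20000 nM in this assay.
Compound 3, `COc1cc(/C=N/Nc2nc(SCc3ccccc3)nc3c2nnn3Cc2ccccc2)cc(OC)c1OC`, gives 4400 nM in this assay.

Compound 1 therefore stands at the top of these values: it sits at the limit of > 64000 nM in this assay, at which 1 of the 3 values shown sits, so only a boundary is known for it, not an exact number. Compound 4, `CCCSc1nc(N/N=C/c2ccc(Br)cc2)c2nnn(Cc3ccccc3)c2n1`, differs from compound 1 in a single place: 4-bromophenyl in place of 2-fluorophenyl on a carbon with a double bond to nitrogen.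

Going by the values given here, only one measured step bears on this change, since compound 3 differs from compound 1 in more than one place and its value can only be set beside the others. That step is an at least 3.2-fold lower number from compound 1 to compound 2 (0.50 log units; beyond the scatter), where the same 2-fluorophenyl on the same carbon was exchanged for another group. It shows that swapping this group can move the number downward beyond the scatter. The entering 4-bromophenyl is not the group tested there, so the size of the effect is uncertain.

A modest lowering of the number is expected, giving an at least 2.1-fold lower number from compound 1 to compound 4 (0.32 log units; beyond the scatter). Compound 4 is estimated at 30000 nM in this assay, within 8000 nM to 90000 nM.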

Compound 4, half-maximal inhibitory concentration: > 64000 nM
Compound 4: no number, only a limit; the forecaster's own chance of this, stated with the estimate: 30%; middle value at least 2.1-fold (0.32 log units) away from the limit.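

In this assay compound 4 gives only a limit of the assay, the same limit that compound 1 gives: the limit of > 64000 nM in this assay, at which 2 of the 4 values shown sit.

As far as these compounds go, the step between these two compounds cannot be read, so it remains unknown how far 4-bromophenyl and 2-fluorophenyl differ on this carbon. The step that can be read is an at least 3.2-fold higher number from compound 2 to compound 4 (0.50 log units; beyond the scatter), with bromo in place of dimethylamino on an aromatic carbon. This shows that exchanging the 2-fluorophenyl group does not by itself bring the number down to a measurable value: of compound 1, compound 2 and compound 4, which differ only in this group, compound 2 alone gives a number rather than a limit.

The compounds shown leave open whether the dimethylamino group is unusual in this respect, or whether another amine on the phenyl ring, such as a plain amino group or a morpholine, would also give a number rather than a limit. They also leave open whether the bromo and dimethylamino groups would stand in the same order if a longer chain replaced the propyl chain on the sulfur.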